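Isopropyl in place of hydrogen on the aryl ether

A few compounds are considered here, and "the series" means these few. Any claim that something is new, unique, unknown or untested is made for them only; others in the source may bear on it.

Measured compounds:
compound 1, `CC(C)(C)c1ccc(OCCCCCn2ccc(=O)[nH]c2=O)cc1`, 40000 nM
compound 2, `N#Cc1ccc(OCCCCCn2ccc(=O)[nH]c2=O)cc1`, 100000 nM
compound 3, `O=c1ccn(CCCCCOc2ccccc2)c(=O)[nH]1`, > 100000 nM

In an ADME assay on HEL cells (Homo sapiens) for cytotoxicity (on this read-out higher numbers stand for lower toxicity in this test and lower numbers for higher toxicity in this test), compound 1 gives 40000 nM and compound 2 gives 100000 nM. Compound 3 gives only a limit, > 100000 nM, so that its place among the numbers shown is open; it sits at the limit of > 100000 nM in this assay, at which 1 of the 3 values shown sits. The step from compound 3 to compound 4, `CC(C)c1ccc(OCCCCCn2ccc(=O)[nH]c2=O)cc1`, is isopropyl in place of hydrogen on an aromatic carbon. Going by the values given here, two measured steps bear on it: an at least 2.5-fold higher number from compound 1 to compound 3 (0.39 log units; beyond the scatter), and a 2.5-fold higher number from compound 1 to compound 2 (0.40 log units; beyond the scatter). Both run away from the tert-butyl compound toward higher numbers, and the step to compound 4 runs the other way, from hydrogen toward a group that is smaller than tert-butyl. Compound 4 is therefore expected to give a number below the limit of compound 3 and no lower than that of compound 1, with an at least 1.6-fold lower number from compound 3 to compound 4 (0.22 log units; that floor lies within the scatter) as the expected step. The estimate for compound 4 is 60000 nM, between 30000 nM and 100000 nM.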

Compound 4, half-maximal cytotoxic concentration: > 100000 nM
Compound 4: no number, only a limit; the forecaster's own chance of this, stated with the estimate: 40%; middle value at least 1.6-fold (0.22 log units) away from the limit.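

In this assay, compound 4 gives only a limit, so isopropyl on the aromatic carbon para to a large group leaves the read-out at the same limit as hydrogen: the limit of > 100000 nM in this assay, at which 2 of the 4 values shown sit. Among the alkyl groups shown, a measured number under that limit thus appears only with the tert-butyl of compound 1, and hydrogen in place of methyl on a saturated chain carbon bound to an aromatic carbon and two saturated chain carbons gives an at least 2.5-fold higher number from compound 1 to compound 4 (0.39 log units; beyond the scatter). Isopropyl in place of cyano on an aromatic carbon gives a number no lower from compound 2 to compound 4 (the limit leaves the size open). The step from compound 3 to compound 4 cannot be read.

The compounds shown leave open how far compound 3 and compound 4 lie beyond the limit, so hydrogen and isopropyl cannot be ranked here. Also open, as far as these compounds go, is how an amine or a carboxylic acid at this place, or a longer chain in the linker, would read in this assay.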